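The source may hold more compounds than are shown below. What is called first, only, known or untested is meant among the compounds shown, and "the series" means these compounds.

In an ADME assay on microsomes from liver (Homo sapiens) for metabolic stability, with a stated time of 10 min (a lower number here means that less of the compound is left, a higher number that more of the compound is left), compound 1 (`O=C(O)C1CCC(O)(C(=O)N2CC[C@](c3ccc(C(F)(C(F)(F)F)C(F)(F)F)cc3)(S(=O)(=O)c3ccc(F)cc3)C2)CC1`) gives 100%; 95% (2 entries) and compound 2 (`O=C1NC(=O)C2(CCC(C(=O)N3CC[C@](c4ccc(C(F)(C(F)(F)F)C(F)(F)F)cc4)(S(=O)(=O)c4ccc(F)cc4)C3)CC2)N1`) gives 84%; 93% (2 entries), each from two entries. Compound 3 (`O=C([C@H]1CC[C@H](CO)CC1)N1CC[C@](c2ccc(C(F)(C(F)(F)F)C(F)(F)F)cc2)(S(=O)(=O)c2ccc(F)cc2)C1`) gives 75%, the only number shown for it, while two further entries carry no single number. This value falls short of both entries for compound 1 in the several entries of compound 1 in this assay, 100%; 95% (2 entries), whereas one of the entries for compound 2 in the several entries of compound 2 in this assay, 84%; 93% (2 entries) lies within the usual scatter of it.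

The next change leads to compound 4 (`O=C(N1CC[C@](c2ccc(C(F)(C(F)(F)F)C(F)(F)F)cc2)(S(=O)(=O)c2ccc(F)cc2)C1)C1(O)CCS(=O)(=O)CC1`), with 4-hydroxy-1,1-dioxothian-4-yl in place of 4-(hydroxymethyl)cyclohexyl on a carbonyl carbon. Among the compounds with values here, no measured step isolates this change, so the expectation is only indirect. It rests on compound 1 at 100%; 95% (2 entries) and compound 2 at 84%; 93% (2 entries), neither of which carries the 4-(hydroxymethyl)cyclohexyl group. A modest upward step is expected, a number 10 percentage points higher from compound 3 to compound 4 (within the scatter). In this assay, compound 4 is estimated at 85%, with an expected range of 68% to 100%.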

Compound 4, percent of the compound remaining: 100%
Estimate against measurement, compound 4: 15 percentage points below; measured number inside the range.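

Replacing 4-(hydroxymethyl)cyclohexyl with 4-hydroxy-1,1-dioxothian-4-yl on a carbonyl carbon gives, in this assay, a number 25 percentage points higher from compound 3 to compound 4 (beyond the scatter), the only step shown that isolates a change at this place. The read-out therefore responds to the group on this carbonyl carbon while the rest of the molecule stays the same. Compound 4, at 100%, also shows that a high reading at this place does not require the carboxylic acid of compound 1, whose values serve as the reference: the several entries of compound 1 in this assay, 100%; 95% (2 entries)

The step leaves open which part of the new group accounts for the difference, as the ring sulfur with its two oxygens and the hydroxy group on the ring enter together in compound 4. A plain thiane ring without the two sulfur oxygens, or an amine in place of the hydroxy group, lies outside the compounds shown.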